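Phenyl ether swap in a quinoline amine series

A few compounds are considered here, and "the series" means these few. Any claim that something is new, unique, unknown or untested is made for them only; others in the source may bear on it.

Compound 1 `COc1cccc(Oc2ccc3c(NCCCNCc4cccc(OC)c4O)ccnc3c2)c1`: 9.28
Compound 2 `COc1cccc(CNCCCNc2ccnc3cc(Oc4cccc(N(C)C)c4)ccc23)c1O`: 9.28

In a physicochemical assay for acid dissociation, compound 2 gives 9.28 and stands level, at the digits shown, with compound 1, which in this assay gives 9.28. For the measured compounds named here, the one measured step that connects them, no change at the digits printed from compound 1 to compound 2 (within the scatter), exchanged a dimethylamino for a methoxy on an aromatic carbon and left the read-out where it was.

Compound 3 `COc1ccccc1Oc1ccc2c(NCCCNCc3cccc(OC)c3O)ccnc2c1` carries 2-methoxyphenyl in place of 3-(dimethylamino)phenyl on an oxygen on an aromatic ring. The change again falls on the same phenyl ether that was altered in the step from compound 1 to compound 2, and that step, no change at the digits printed from compound 1 to compound 2 (within the scatter), produced nothing beyond the scatter. Going by the values given here, no other measured pair in the set informs this exchange, so the only guide is that one flat step.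

On that basis compound 3 is expected to give 9.28 in this assay, with a range of 9 to 9.6. The step of no change at the digits printed from compound 2 to compound 3 (within the scatter) is therefore estimated to be no change beyond the scatter, in either direction.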

Compound 3, acid dissociation constant: 9.28
Estimate against measurement, compound 3: no gap at the digits printed; low and high end bracket the measured number.
By their numbers in this assay, from the lowest: compounds 1, 2 and 3 (each within the scatter of the next).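

In this assay, replacing 3-(dimethylamino)phenyl with 2-methoxyphenyl on an oxygen on an aromatic ring gave no change at the digits printed from compound 2 to compound 3 (within the scatter), and the direct exchange of 3-methoxyphenyl for 2-methoxyphenyl gave no change at the digits printed from compound 1 to compound 3 (within the scatter). For the compounds shown here, the earlier compounds had tested only one exchange of the substituent on this phenyl ether, whereas the set now holds three aryl groups at this place, all level in this read-out, and it includes a pair that differs only in where the methoxy group stands on the phenyl ring. Going by these compounds alone, nothing available explains this flat result, and the data show only that these three groups cannot be told apart by this measurement.

What the compounds shown leave open is whether the read-out would stay level with a carboxylic acid or a primary amine on the phenyl ring, or with a saturated cyclohexyl ring in place of the phenyl ring. All three compounds also share the rest of their structure, so they give no reading on a longer chain in the part that carries the amine, or on any other change away from this phenyl ether.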